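The source may hold more compounds than are shown below. What is called first, only, known or untested is meant among the compounds shown, and "the series" means these compounds.

In an ADME assay on MT4 cells (Homo sapiens) for cytotoxicity, read by MTT assay, with a stated time of 5 days (a lower number here means that less compound is tolerated, a higher number that more compound is tolerated), compound 1 `Cc1cc(C)cc(S(=O)(=O)c2c(C(=O)NC3CN(CC(N)=O)C3)[nH]c3ccc(Cl)cc23)c1` gives 25500 nM. Compound 2 `CCS(=O)(=O)NC(=O)c1[nH]c2ccc(Cl)cc2c1S(=O)(=O)c1cc(C)cc(C)c1` gives only a limit, > 283000 nM, and not a number. For the measured compounds named here, of the two compounds measured so far, compound 2 therefore stands at the tolerated end, with no exact value to start from.

Compound 3 `Cc1cc(C)cc(S(=O)(=O)c2c(C(=O)NS(=O)(=O)C(F)(F)F)[nH]c3ccc(Cl)cc23)c1` differs from compound 2 by one small swap: trifluoromethyl in place of ethyl on a sulfonyl sulfur. Going by the values given here, no measured step touches the group on that sulfur. The nearest evidence is an at least 11-fold higher number from compound 1 to compound 2 (1.04 log units; beyond the scatter), a large step beyond the scatter, which came with ethylsulfonyl in place of 1-(carbamoylmethyl)azetidin-3-yl on an amide-type nitrogen. Compound 3 keeps a sulfonyl on that nitrogen, so a high number is expected again, and the assay may once more report only a limit. The expected change is an at least 1.4-fold lower number from compound 2 to compound 3 (0.15 log units; that floor lies within the scatter), which is an estimate of no clear step beyond the scatter. In this assay the estimate for compound 3 is 200000 nM, expected to lie between 60000 nM and 300000 nM.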

Compound 3, half-maximal cytotoxic concentration: 141000 nM
Estimate against measurement, compound 3: 1.4-fold (0.15 log units) above, within the range that was stated.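

For the compounds shown here, compound 3 gives the first exact number for a sulfonyl group on the amide-type nitrogen in this assay, so this position can now be read as a value and not only as a limit. Compound 2 has no exact number, only a limit: the limit of > 283000 nM in this assay, at which 1 of the 3 values shown sits. Trifluoromethyl in place of ethyl on the sulfonyl sulfur comes with an at least 2.0-fold lower number from compound 2 to compound 3 (0.30 log units; that floor lies within the scatter), which gives this change a floor but no true size, while a sulfonyl group on that nitrogen still stands clear of the 1-(carbamoylmethyl)azetidin-3-yl group, with a 5.5-fold higher number from compound 1 to compound 3 (0.74 log units; beyond the scatter) as the step for (trifluoromethyl)sulfonyl in its place.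

From the compounds shown here alone, the true distance between ethyl and trifluoromethyl on the sulfur stays open, since one end of that step is a limit and its floor does not go beyond the usual scatter. Going by these compounds, how a methyl group, a phenyl ring or a longer chain on the same sulfur would sit in this assay also stays open, as does whether any such group would give a reading rather than a limit.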